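From 2,5-dimethylphenyl to 4-methylbenzyl on the amide-type nitrogen

The compounds below may be only part of what the source reports. "The series", "measured", "known", "first", "only" and "open" are said of these compounds alone.

Among the compounds with values here, in a functional assay on A549 cells (Homo sapiens) for inhibition, read by MTT assay, with a stated time of 48 h (on this read-out lower numbers stand for stronger inhibition and higher numbers for weaker inhibition), compound 1 `COc1ccc2c(=O)c(/C=C/C(=O)Nc3cc(C)ccc3C)coc2c1` gives 15500 nM as the only numerical value so far. Compound 2 (`O=C(/C=C/c1coc2cc(O)ccc2c1=O)NCc1ccc(F)cc1`) also bears a substituted benzyl on that nitrogen and stands only at a limit of this assay (> 100000 nM). Compound 3 (`COc1ccc2c(=O)c(/C=C/C(=O)NCc3ccc(C)cc3)coc2c1`) keeps the core of compound 1 and carries 4-methylbenzyl in place of 2,5-dimethylphenyl on an amide-type nitrogen. In this assay a move toward weaker inhibition is expected, estimated as a 2.6-fold higher number from compound 1 to compound 3 (0.41 log units; beyond the scatter) and so beyond the scatter. For compound 3 the expected value is 40000 nM (estimated range 14000 nM to 100000 nM).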

Compound 3, half-maximal inhibitory concentration: > 100000 nM
Compound 3 gave a limit, no number (the forecaster's own chance of this, stated with the estimate: 30%); at least 2.5-fold (0.39 log units) between middle value and limit.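

In this assay, placing 4-methylbenzyl in place of 2,5-dimethylphenyl on the amide-type nitrogen of the shared core gives an at least 6.4-fold higher number from compound 1 to compound 3 (0.80 log units; beyond the scatter). This shows that inhibition at this position depends on how the group is joined and arranged, even though the two groups have the same count of atoms. The value of compound 3 is a limit, not a number, so the true size of the step remains unknown: the limit of > 100000 nM in this assay, at which 2 of the 3 values shown sit.

From the compounds shown here alone, it remains open whether unsubstituted phenyl or a longer chain such as 2-phenylethyl on that nitrogen would give a measurable value.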